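Methyl on an aromatic nitrogen of compound 2

The source may hold more compounds than are shown below. What is called first, only, known or untested is meant among the compounds shown, and "the series" means these compounds.

- compound 1 `Nc1nn(C(=O)c2ccc([N+](=O)[O-])cc2)c(N)c1/N=N/c1ccc(O)cc1` gives > 100000 nM (a limit of the assay, not a number)
- compound 2 `Nc1n[nH]c(N)c1/N=N/c1ccc(O)cc1` gives 24900 nM
- compound 3 `Nc1n[nH]c(N)c1/N=N/c1cc[n+]([O-])cc1` gives > 100000 nM (a limit of the assay, not a number)

All three compounds were tested in a functional assay on RPMI-8226 cells (Homo sapiens) for cytotoxicity, read by fluorescence, with a stated time of 72 h; on this read-out lower numbers stand for stronger inhibition and higher numbers for weaker inhibition. Compound 2 is the only one of them with an actual number, at 24900 nM. The other two results give no number to compare it with, and the set is bounded by the limit of > 100000 nM in this assay, at which 2 of the 3 values shown sit.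

Compound 4 `Cn1nc(N)c(/N=N/c2ccc(O)cc2)c1N` has not yet been measured. It differs from compound 2 by one change, methyl in place of hydrogen on an aromatic nitrogen. Going by the values given here, no step between measured compounds shows what such a change does. The expectation is therefore a cautious one: a modest shift towards weaker inhibition in this assay, not far beyond the usual scatter, with a real chance that the result reaches the limit of the assay. The expected size of the change is a 2.0-fold higher number from compound 2 to compound 4 (0.30 log units; within the scatter). Compound 4 is estimated at 50000 nM, with an expected range of 18000 nM to 100000 nM.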

Compound 4, half-maximal inhibitory concentration: > 100000 nM
Compound 4: a limit, no number; the forecaster's own chance of this, stated with the estimate: 45%; middle value at least 2.0-fold (0.30 log units) from the limit.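

In this assay compound 4 gives > 100000 nM, which is a limit of the assay and not a number. Methyl in place of hydrogen on this aromatic nitrogen gives an at least 4.0-fold higher number from compound 2 to compound 4 (0.60 log units; beyond the scatter), the first step in this set that can be read between two measured compounds, and it shows that even this single added carbon at this position moves the read-out beyond the scatter towards weaker inhibition. The step gives only a minimum size, and compound 2 remains the only compound here with an actual number, so the set offers no further value against which to size the change: the limit of > 100000 nM in this assay, at which 3 of the 4 values shown sit.

The compounds shown leave open whether another group on this aromatic nitrogen, such as an ethyl group or a longer chain ending in an amine, would also reach the limit or would keep a measurable value. Also open, going by these compounds, is whether methyl on one of the amino groups of the shared core, rather than on the aromatic nitrogen, would give a step of similar size.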